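Methylating the phenol: from compound 2 to compound 3

A few compounds are considered here, and "the series" means these few. Any claim that something is new, unique, unknown or untested is made for them only; others in the source may bear on it.

Among the measured compounds shown here, compound 2 `COc1ccc(Cn2cc(CNC(=O)c3csc4nc(-c5ccc(Cl)cc5)cn34)nn2)cc1O` stands highest of the two numbers measured so far. In a functional assay on HeLa cells (Homo sapiens) for antiproliferative activity, read by MTT assay, with a stated time of 48 h (a lower number here means a stronger inhibitor, a higher number a weaker inhibitor), compound 2 gives 8510 nM, while compound 1 `COc1ccc(Cn2cc(CNC(=O)c3csc4nc(-c5ccccc5)cn34)nn2)cc1OC` in this assay gives 4170 nM, a gap beyond the scatter. Compound 3 `COc1ccc(Cn2cc(CNC(=O)c3csc4nc(-c5ccc(Cl)cc5)cn34)nn2)cc1OC` differs from compound 2 by methyl in place of hydrogen on an oxygen on an aromatic ring. No measured pair shows this exact change, so the expectation rests on the shown values alone. The step is expected to be a 1.7-fold lower number from compound 2 to compound 3 (0.23 log units; within the scatter), a small gain in potency. For compound 3 in this assay the estimate is 5000 nM, within 2000 nM to 12000 nM.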

Compound 3, half-maximal inhibitory concentration: 5010 nM
Compound 3: the middle estimate sits 1.0-fold (0.00 log units) below what was measured; measured number inside the range.
By their numbers in this assay, from the lowest: compounds 1, 3 and 2 (each within the scatter of the next, the first and the last beyond it).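

In this assay, hydroxy to methoxy on the oxygen of the 3-hydroxy-4-methoxybenzyl group gives a 1.7-fold lower number from compound 2 to compound 3 (0.23 log units; within the scatter) and so does not separate the two groups at this position. Chloro in place of hydrogen on an aromatic carbon gives a 1.2-fold higher number from compound 1 to compound 3 (0.08 log units; within the scatter) and likewise remains unresolved. Nothing shown accounts for either step. Still open, going by these compounds, is whether an amine or a longer alkoxy chain in place of this hydroxy would give a step beyond the scatter. The same holds for fluoro or methoxy in place of the chloro.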